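The source may report more compounds than this note shows. Statements on the series, on what has been measured and on what is new or still open speak of the compounds shown alone.

Measured compounds:
- compound 1, `COc1ccccc1S(=O)(=O)/C=C/c1ccc(Cl)cn1`: 92.6%
- compound 2, `COc1cccc(S(=O)(=O)/C=C/c2ccccn2)c1`: 98.9%
- compound 3, `COc1cccc(S(=O)(=O)/C=C/c2cccnc2)c1`: 90.8%

All three numbers come from an ADME assay on BV-2 cells (Mus musculus) for cytotoxicity, with a stated time of 24 h, tested at 50 uM; on this read-out lower numbers stand for a stronger effect and higher numbers for a weaker effect at the one concentration tested. Among the measured compounds shown here, the three values lie within the scatter of one another, so no ordering can be read among them: compound 3 differs from compound 1 by a step that is within the scatter, and the one single-point step in this set, a number 8.1 percentage points lower from compound 2 to compound 3 (within the scatter), is also within the scatter. On these numbers, then, compound 3 is indistinguishable from the other two.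

Compound 4, `COc1cccc(S(=O)(=O)/C=C/c2cccnc2Cl)c1`, is not yet measured. It differs from compound 3 in one place: chloro in place of hydrogen on an aromatic carbon. For the measured compounds named here, no measured step introduces a chloro group on its own, so nothing in the data speaks directly to this change; compound 1 carries a chloro group but differs from compound 3 in more than one place, and its value sits within the scatter of that of compound 3. Going by the values given here, the only step at hand, from compound 2 to compound 3, was within the scatter. The step expected here, a number 0.2 percentage points higher from compound 3 to compound 4 (within the scatter), is therefore estimated to stay within the scatter. Compound 4 is expected to give about 91%, with a range from 78% to 100%.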

Compound 4, a percentage reported as activity, at one concentration (the size of the read-out at that concentration, not a potency): 78.8%
The estimate for compound 4 lay 12.2 percentage points above the measured number; measured number inside the range.
By their numbers in this assay, from the lowest: compound 4; then compounds 3, 1 and 2 (each within the scatter of the next).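

Placing chloro in place of hydrogen on an aromatic carbon, next to the ring nitrogen and ortho to a large group, gives a number 12 percentage points lower from compound 3 to compound 4 (beyond the scatter) in this assay and is the only step shown that lies beyond the scatter. This shows that a single added chlorine at this position can change the read-out by a modest but readable amount, towards a stronger effect at the one concentration tested, which the earlier step between pyridin-2-yl and pyridin-3-yl could not show. The data available give no explanation for this shift.

From the compounds shown here alone, it remains open whether the change is specific to chloro, or whether a methyl group or an amine at this same position would move the number as well. Among the compounds shown here, it also remains open whether chloro elsewhere on this ring would have a similar effect, since no single-place step shows this.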